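Acylating the Amine Tail on the Shared Core

The source may report more compounds than this note shows. Statements on the series, on what has been measured and on what is new or still open speak of the compounds shown alone.

Compound 2, `CCn1nc(C)cc1C(=O)Nc1nc2cc(C(N)=O)cc(OC)c2n1CCCN`, and compound 1, `COc1cc(C(N)=O)cc2nc(NC(=O)CCc3ccccc3)n(CCCNC(=O)OCc3ccccc3)c12`, share one core and differ at the chain nitrogen and in the amide group. In an assay for activation of interferon regulatory factor 3 (Homo sapiens), read by a luciferase reporter, with a stated time of 20 h (a lower number here means that less compound is needed, a higher number that more compound is needed for the effect), compound 1 reaches only a limit of the assay, > 100000 nM. In this assay compound 2 likewise reaches only a limit, > 100000 nM. Among the compounds with values here, both values stand at the same limit, (the limit of > 100000 nM in this assay, at which 2 of the 2 values shown sit), so no real number is known for either compound and no measured step between two compounds can be drawn.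

Compound 3, `CCn1nc(C)cc1C(=O)Nc1nc2cc(C(N)=O)cc(OC)c2n1CCCNC(=O)CCc1cccnc1`, differs from compound 2 in one place: (2-(pyridin-3-yl)ethyl)carbonyl in place of hydrogen on an amine nitrogen. Compound 2 shows only a limit in this assay, so this change cannot be anchored to a measured number. The step of an at least 1.6-fold lower number from compound 2 to compound 3 (0.22 log units; that floor lies within the scatter) is expected to be no more than the usual scatter, with wide uncertainty. For compound 3 the estimate in this assay is 60000 nM, ranging from 5000 nM to 300000 nM.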

Compound 3, half-maximal effective concentration: > 100000 nM
Compound 3: a limit, no number; the forecaster's own chance of this, stated with the estimate: 65%; middle value at least 1.6-fold (0.22 log units) from the limit.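

Compound 3 reaches only a limit in this assay, > 100000 nM. Compound 2 also stands at a limit, so no step from compound 2 to compound 3 can be read: the limit of > 100000 nM in this assay, at which 3 of the 3 values shown sit.

The compounds shown leave open which group on the amine nitrogen, if any, would give a real number in this assay.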